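Chalcone pyrazole analogs tested against PC-3 cells

The compounds below may be only part of what the source reports. "The series", "measured", "known", "first", "only" and "open" are said of these compounds alone.

Compound 1 `Cc1ccc(-c2nn(-c3ccccc3)cc2/C=C/C(=O)c2ccc(OCc3ccccc3)c3c2OC(C)(C)C3)cc1` gives > 100000 nM in a functional assay on PC-3 cells (Homo sapiens) for antiproliferative activity, read by MTT assay, with a stated time of 48 h (a lower number here means a stronger inhibitor, a higher number a weaker inhibitor), a limit of the assay.
Compound 2 `CC1(C)Cc2c(ccc(C(=O)/C=C/c3cn(-c4ccccc4)nc3-c3cccc([N+](=O)[O-])c3)c2OCc2ccccc2)O1` gives > 100000 nM in this assay, a limit of the assay.
Compound 3 `COc1ccc(/C=C/C(=O)c2ccc(OCc3ccccc3)c3c2OC(C)(C)C3)cc1` gives 13500 nM in this assay.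

Compound 2 stands at the limit of the assay in this assay, and it shares that position with one other measured compound, as the limit of > 100000 nM in this assay, at which 2 of the 3 values shown sit, shows; only compound 3 gives a number. Compound 4 `Cc1ccc(-c2nn(-c3ccccc3)cc2/C=C/C(=O)c2ccc3c(c2OCc2ccccc2)CC(C)(C)O3)cc1` has not yet been measured in this assay. It differs from compound 2 by 4-methylphenyl in place of 3-nitrophenyl on an aromatic carbon. Among the compounds with values here, no measured pair shows this exact change, so no step can be read off. Compound 1 carries the same 4-methylphenyl group and sits at the limit of the assay with > 100000 nM, so compound 4 is expected to stay close to the limit as well, and the step of a number no higher from compound 2 to compound 4 (the limit leaves the size open) is expected to be none beyond the scatter. The estimate for compound 4 in this assay is 100000 nM, within 30000 nM to 300000 nM.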

Compound 4, half-maximal inhibitory concentration: 24200 nM
The estimate for compound 4 lay 4.1-fold (0.62 log units) above the measured number; the measured number lies below the stated range.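

Within the data shown here, this is the first sign that the group on this aromatic carbon can move the read-out in this assay: the change from 3-nitrophenyl to 4-methylphenyl gives an at least 4.1-fold lower number from compound 2 to compound 4 (0.61 log units; beyond the scatter). Going by these compounds, the full size of that step stays open, since compound 2 rests at a limit of the assay: the limit of > 100000 nM in this assay, at which 2 of the 4 values shown sit. Compound 1 carries the same 4-methylphenyl group and its > 100000 nM is a limit of the assay, so this group alone does not secure a measurable number.

The compounds shown leave open whether the shift follows from the methyl group, from the loss of the nitro group, or from where the group sits on the phenyl ring, and an unsubstituted phenyl would help to separate these. They also leave open how an amine or a carboxylic acid on that phenyl ring would read in this assay.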